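A few compounds are considered here, and "the series" means these few. Any claim that something is new, unique, unknown or untested is made for them only; others in the source may bear on it.

Measured so far in an assay on membranes from brain for binding affinity to adenosine receptor A1 (Rattus norvegicus), read by radioligand binding, tested at 20 uM; on this read-out higher numbers stand for more inhibition at the one concentration tested (going by the name of the read-out) and lower numbers for less inhibition:
- compound 1, `Cn1c(=O)[nH]c2c(cnn2-c2ccc(N)cc2)c1=N`: 0%
- compound 2, `Cn1c(=O)[nH]c2c(cnn2-c2ccccc2Cl)c1=N`: 7%
- compound 3, `Cn1c(=O)[nH]c2c(cnn2-c2ccc(Cl)cc2)c1=N`: 37%

Compound 3 stands highest of the three numbers in this assay. Its nearest neighbour on the numbers is compound 2, whose value is beyond the scatter below it; compound 1 lies furthest below, also beyond the scatter. For the measured compounds named here, the one single-point step measured is a number 37 percentage points higher from compound 1 to compound 3 (beyond the scatter), a large gain for chloro in place of amino on an aromatic carbon. Going by the values given here, compound 2 also carries a single chloro, at another position of the same ring, and its value shows no comparable gain; no step between compound 2 and compound 3 is counted here.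

Compound 4, `Cn1c(=O)[nH]c2c(cnn2-c2ccc(Cl)cc2Cl)c1=N`, is compound 3 with a second chloro added: chloro in place of hydrogen on an aromatic carbon.

What bears on this step is only the chloro-for-amino step into compound 3, which shows a higher number with chloro in place of amino, and the low value of compound 2, which shows that a chloro at a second position need not bring a higher number. Neither is a direct precedent for a second chloro on top of the first. The expectation is therefore no step beyond the scatter, a number 2 percentage points lower from compound 3 to compound 4 (within the scatter), with wide uncertainty in both directions. Compound 4 is estimated at 35%, in a range from 10% to 60%.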

Compound 4, a percentage reported as inhibition, at one concentration (the size of the read-out at that concentration, not a potency): 9%
Estimate against measurement, compound 4: 26 percentage points above, outside the stated range (below it).
By their numbers in this assay, from the lowest: compounds 1, 2 and 4 (each within the scatter of the next); then compound 3.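

In this assay, chloro in place of hydrogen, ortho to a large group and meta to a chloro group, gives a number 28 percentage points lower from compound 3 to compound 4 (beyond the scatter), so the gain seen in a number 37 percentage points higher from compound 1 to compound 3 (beyond the scatter) does not hold once this position is also substituted. Read from the other side, the second chloro brings a number 2 percentage points higher from compound 2 to compound 4 (within the scatter), so the chloro that sets compound 3 apart from compound 1 gives no readable gain when the chloro of compound 2 is also on the ring, and the two chloro groups together do not add up to a higher number. No measurement available here accounts for this loss.

The compounds shown leave open whether the drop belongs to chloro itself or would also follow a methyl or a methoxy group at the position ortho to a large group. Equally open, on these data alone, is whether a fluoro or an amine there, with the other chloro kept, would stay near compound 3 at 37% in this assay.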